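Chalcone-type series: fluoro to methoxy on the aryl ring

The source may hold more compounds than are shown below. What is called first, only, known or untested is meant among the compounds shown, and "the series" means these compounds.

Of the compounds shown here, two have numbers so far. Among the measured compounds shown here, compound 1 `COc1cc(C(=O)/C=C/c2c(-c3cccs3)nc3ccccn23)cc(OC)c1OC` and compound 2 `COc1cc(C(=O)/C=C/c2c(-c3ccc(F)cc3)nc3ncccn23)cc(OC)c1OC` share the trimethoxyphenyl enone and differ in both the bicyclic core and the aryl group attached to it, so no single-point step connects them. In a functional assay on DU-145 cells (Homo sapiens) for inhibition, read by sulforhodamine B assay, with a stated time of 48 h (a lower number here means a stronger inhibitor of growth, a higher number a weaker inhibitor of growth), compound 1 gives 1900 nM, and in this assay compound 2 gives 1630 nM. The two values fall within the scatter of each other, so compound 2 cannot be set apart from compound 1 on these numbers; it simply carries the lower of the two figures.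

Compound 3 `COc1ccc(-c2nc3ncccn3c2/C=C/C(=O)c2cc(OC)c(OC)c(OC)c2)cc1` keeps the core of compound 2 and changes only the aryl group: methoxy in place of fluoro on an aromatic carbon. Cut one bond further out, this reads 4-fluorophenyl to 4-methoxyphenyl.

For the measured compounds named here, no measured pair shows what such a change does in this assay, so the expectation rests on compound 2 alone. The step from compound 2 to compound 3 is expected to be small, a 1.1-fold lower number from compound 2 to compound 3 (0.04 log units; within the scatter), and not beyond the scatter in either direction. Compound 3 is therefore estimated at 1500 nM, with a range from 700 nM to 3500 nM.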

Compound 3, concentration for 50% growth inhibition: 2550 nM
Compound 3: the middle estimate sits 1.7-fold (0.23 log units) below what was measured; the measured number falls inside the stated range.
By their numbers in this assay, from the lowest: compounds 2, 1 and 3 (each within the scatter of the next).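

Among the compounds shown here, this is the first single-point step. With the core of compound 2 held fixed, methoxy in place of fluoro on the aromatic carbon para to a large group gives, in this assay, a 1.6-fold higher number from compound 2 to compound 3 (0.19 log units; within the scatter), so on this pair the exchange cannot be told apart from repeated-measurement scatter, and fluoro and methoxy at this position are not separated by growth inhibition in these cells. No independent measurement is at hand that bears on this pair.

Left open is whether a group of a different kind at this position, such as an amine, a carboxylic acid or a longer chain like butoxy, would produce a step beyond the scatter. Also open, on these data alone, is whether methoxy in place of fluoro reads the same on another core, such as that of compound 1, since this single pair covers only the core of compound 2.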